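This account rests on a few compounds, and the source may have more. Where it says the series, first, only, none or still open, it means among the compounds named here.

Measured compounds:
compound 1, `Cc1c(OCCCCOc2ccccc2C(=O)O)ccc(C(=O)CC2CCCC2)c1C`: 28%
compound 2, `CCC(=O)c1ccc(OCCCCOc2ccc(F)c(C(=O)O)c2)c(C)c1O`: 18.4%
compound 3, `CCCC(=O)c1ccc(OCCCCOc2cccc(C(=O)O)c2C)c(C)c1O`: 53%

In an assay on HEK293 cells for positive allosteric modulation of metabotropic glutamate receptor 3 (Rattus norvegicus), read by thallium flux, with a stated time of 2.5 min (a higher number here means a larger maximal response, a lower number a smaller maximal response), compound 2 gives the lowest of the three numbers. Compound 1 lies within the scatter of compound 2, so the two cannot be ordered. Compound 3 stands beyond the scatter above compound 2. Within the data shown here, no pair of measured compounds differs in one place only, so no measured step guides the change ahead.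

The new compound is compound 4, `Cc1c(OCCCCOc2ccc(F)c(C(=O)O)c2)ccc(C(=O)CC(C)C)c1O`. Relative to compound 2 the change is isopropyl in place of methyl on a saturated chain carbon bound to a carbonyl carbon. The chain on the carbonyl grows. Compound 3, which also carries a longer chain on the carbonyl than compound 2, reaches a higher number, but compound 3 differs from compound 2 elsewhere as well, so this comparison is loose and rests on two values only.

In this assay, among the measured compounds shown here, compound 4 is expected to show a modest upward step, a number 13.6 percentage points higher from compound 2 to compound 4 (beyond the scatter), with a wide range because no clean step is known. Compound 4 is expected to reach 32%, between 15% and 55%.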

Compound 4, largest response reached (reported as percent of maximum), in percent of the reference or control that the assay uses: 81.7%
Beside the measured number, compound 4's estimate is 49.7 percentage points below it; measured number above the stated range.
By their numbers in this assay, from the lowest: compounds 2 and 1 (each within the scatter of the next); then compound 3; then compound 4.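

In this assay, the saturated chain carbon bound to a carbonyl carbon proves a highly responsive place in this series: isopropyl in place of methyl gives a number 63.3 percentage points higher from compound 2 to compound 4 (beyond the scatter). Among these compounds, this is the first single-place step available, and it is large. The change from propanoyl to isobutylcarbonyl is therefore enough to raise the maximal response substantially while the rest of compound 2 stays unchanged. Nothing measured here bears on why the step is so large.

One step cannot show whether the gain follows the branching or the added carbon count alone. A straight propyl chain and a tert-butyl group on the same saturated chain carbon would address that, and the compounds shown also leave open whether the step holds on other versions of the shared core.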